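Swapping a Chlorobenzyl Cap for Cyclopentyl: an Expected Value

The compounds below may be only part of what the source reports. "The series", "measured", "known", "first", "only" and "open" are said of these compounds alone.

Three compounds have been measured in an assay on isolated protein for inhibition of protein deacetylase HDAC6 (Homo sapiens), with a stated time of 60 min; on this read-out higher numbers stand for weaker inhibition and lower numbers for stronger inhibition:

Compound 1, `O=C(CCCCCn1cc(Nc2ncc3ccn(Cc4ccccc4Cl)c3n2)cn1)NO`, gives 45 nM.
Compound 2, `O=C(CCCCCCn1cc(Nc2ncc3ccn(Cc4ccccc4Cl)c3n2)cn1)NO`, gives 41.5 nM.
Compound 3, `O=C(CCCCCn1cc(Nc2ncc3ccn(Cc4cccc(Cl)c4)c3n2)cn1)NO`, gives 34.4 nM.

Compound 2 stands second highest of the three numbers; its nearest neighbour is compound 1, at a difference within the scatter, and its furthest is compound 3, also within the scatter. The two measured steps are small: a 1.1-fold lower number from compound 1 to compound 2 (0.04 log units; within the scatter), and a 1.3-fold lower number from compound 1 to compound 3 (0.12 log units; within the scatter).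

Compound 4, `O=C(CCCCCCn1cc(Nc2ncc3ccn(C4CCCC4)c3n2)cn1)NO`, is not yet measured. It differs from compound 2 by cyclopentyl in place of 2-chlorobenzyl on an aromatic nitrogen. Among the compounds with values here, neither measured step covers this change; only the step from compound 1 to compound 3 touches the same group, and it changed the position of the chlorine rather than removing the aromatic ring altogether, with no movement beyond the scatter. The data therefore give no direct guide. An estimate for compound 4 of 75 nM, with a range of 25 nM to 250 nM, seems reasonable. This estimate means a step of a 1.8-fold higher number from compound 2 to compound 4 (0.26 log units; within the scatter), a modest weakening that may or may not exceed the scatter, and it is expected rather than known.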

Compound 4, half-maximal inhibitory concentration: 22 nM
Estimate against measurement, compound 4: 3.4-fold (0.53 log units) above; the whole stated range lies above it.
By their numbers in this assay, from the lowest: compounds 4, 3, 2 and 1 (each within the scatter of the next, the first and the last beyond it).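

In this assay, putting cyclopentyl in place of 2-chlorobenzyl on the aromatic nitrogen gives a 1.9-fold lower number from compound 2 to compound 4 (0.28 log units; within the scatter) and so leaves the value within the scatter. The earlier compounds shown here had only moved the chlorine around the aromatic ring, whereas this pair shows that, on the longer chain of compound 2, the chlorine and the six-membered aromatic ring can both go, and the group can shrink from 8 heavy atoms to 5, without a change beyond the scatter. Nothing given here accounts for this tolerance. As far as these compounds go, whether cyclopentyl behaves the same way on the shorter chain of compound 1 remains open. So does whether a cyclohexyl group, an unsubstituted benzyl group or a piperidine ring carrying a basic amine would be tolerated on the same nitrogen.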